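The source may report more compounds than this note shows. Statements on the series, on what has been measured and on what is new or still open speak of the compounds shown alone.

Working notes on the series.

Two members of the series have been measured in an assay on microsomes from intestine for inhibition of acyl-CoA:cholesterol acyltransferase (Oryctolagus cuniculus); on this read-out lower numbers stand for stronger inhibition and higher numbers for weaker inhibition. Compound 1 `Cc1cc(C)c(NC(=O)N(Cc2ccc(-c3nnc(C)o3)cc2)C2CCCCCC2)c(C)c1` gives 27 nM. Compound 2 `Cc1cc(C)c(NC(=O)N(Cc2ccc(-c3cnn(C)c3)cc2)C2CCCCCC2)c(C)c1` gives 47 nM. Within the data shown here, the one step between them, a 1.7-fold higher number from compound 1 to compound 2 (0.24 log units; within the scatter), exchanges one five-membered heteroaryl for another on the same aromatic carbon and stays within the scatter. Among the measured compounds shown here, compound 2 therefore stands at the higher of the two numbers so far, but not separated from compound 1 beyond the scatter.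

The next compound, compound 3 `Cc1cc(C)c(NC(=O)N(Cc2ccc(-n3nccn3)cc2)C2CCCCCC2)c(C)c1`, differs from compound 2 in one place: 2H-1,2,3-triazol-2-yl in place of 1-methyl-1H-pyrazol-4-yl on an aromatic carbon. For the measured compounds named here, the only measured step that bears on this kind of change is the heteroaryl exchange from compound 1 to compound 2, which was within the scatter. With a single comparable step of that size, no movement beyond the scatter is expected in this assay in either direction, and a step of about a 1.0-fold lower number from compound 2 to compound 3 (0.02 log units; within the scatter) is estimated. Compound 3 is accordingly expected to give about 45 nM, with a range from 18 nM to 120 nM.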

Compound 3, half-maximal inhibitory concentration: 130 nM
Compound 3: middle estimate off by 2.9-fold (0.46 log units), on the low side; measured number above the stated range.
By their numbers in this assay, from the lowest: compounds 1 and 2 (each within the scatter of the next); then compound 3.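

The position on the aromatic ring para to a large group does not accept every five-membered heteroaryl alike in this assay: 2H-1,2,3-triazol-2-yl in place of 1-methyl-1H-pyrazol-4-yl gives a 2.8-fold higher number from compound 2 to compound 3 (0.44 log units; beyond the scatter) and so moves the number beyond the scatter, which the exchange of compound 1 for compound 2 did not do. Set against 5-methyl-1,3,4-oxadiazol-2-yl, the same group gives a 4.8-fold higher number from compound 1 to compound 3 (0.68 log units; beyond the scatter) and so stands apart from both earlier groups, while compound 1 and compound 2 remain within the scatter of each other. The data in hand offer nothing that accounts for this separation.

Of the three groups, only 2H-1,2,3-triazol-2-yl carries no methyl, and its ring also differs from the other two, so these compounds do not separate the contribution of the methyl from that of the ring. As far as these compounds go, how a methyl-bearing 1,2,3-triazole would read at this place stays open, as does the reading for a group outside the five-membered heteroaryls, such as an amine or a carboxylic acid.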